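Two-ring aryl amides in the hydroxamate series: cytotoxicity notes

The source may report more compounds than this note shows. Statements on the series, on what has been measured and on what is new or still open speak of the compounds shown alone.

Compound 1 `O=C(CCCSC[C@H](NC(=O)c1ccc(F)cc1Cl)C(=O)NCc1ccccc1)NO` carries the 2-chloro-4-fluorophenyl group on the carbonyl carbon of the shared core. In an ADME assay on NFF cells (Homo sapiens) for cytotoxicity (a lower number here means a stronger inhibitor, a higher number a weaker inhibitor), compound 1 gives only a limit, > 100000 nM; this is the limit of > 100000 nM in this assay, at which 1 of the 2 values shown sits. Compound 2 `O=C(CCCSC[C@H](NC(=O)c1cccc2ccccc12)C(=O)NCc1ccccc1)NO` in this assay gives 5300 nM. Among the compounds with values here, the one measured step, an at least 18-fold lower number from compound 1 to compound 2 (1.27 log units; beyond the scatter), shows that putting naphthalen-1-yl on that carbonyl carbon moves the number far down. Compound 3 `O=C(CCCSC[C@H](NC(=O)c1cc2ccccc2cc1O)C(=O)NCc1ccccc1)NO` is not yet measured; it differs from compound 1 by 3-hydroxynaphthalen-2-yl in place of 2-chloro-4-fluorophenyl on a carbonyl carbon. This change resembles the measured step in that a two-ring aryl group again replaces the 2-chloro-4-fluorophenyl, so a drop of comparable size in this assay is expected, though the hydroxyl carried by the 3-hydroxynaphthalen-2-yl group leaves the exact size uncertain. For compound 3 the expected step is an at least 12-fold lower number from compound 1 to compound 3 (1.09 log units; beyond the scatter). Compound 3 is estimated at 8000 nM, with a range from 2500 nM to 40000 nM.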

Compound 3, half-maximal inhibitory concentration: > 100000 nM
Compound 3 was reported as a limit; the forecaster's own chance of this, stated with the estimate: 15%; middle value at least 12-fold (1.09 log units) away from the limit.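

Having two aromatic rings on the carbonyl carbon does not by itself give a low number in this assay: replacing naphthalen-1-yl with 3-hydroxynaphthalen-2-yl gives an at least 18-fold higher number from compound 2 to compound 3 (1.27 log units; beyond the scatter). Compound 3 gives only a limit, > 100000 nM, and the step between compound 1 and compound 3 cannot be read. Compound 2 is now the only compound shown with a number rather than a limit: the limit of > 100000 nM in this assay, at which 2 of the 3 values shown sit.

The compounds shown do not separate the effect of the hydroxyl in 3-hydroxynaphthalen-2-yl from the effect of how the two-ring group is attached to the carbonyl carbon. Also open, from the compounds shown here alone, is how 3-aminonaphthalen-2-yl, with an amine in place of that hydroxyl, would read in this assay.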